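Swapping thiophen-2-yl for 4-chlorophenyl

A few compounds are considered here, and "the series" means these few. Any claim that something is new, unique, unknown or untested is made for them only; others in the source may bear on it.

Measured so far in a functional assay on MDA-MB-231 cells (Homo sapiens) for inhibition, read by MTT assay, with a stated time of 48 h; a higher number here means a weaker inhibitor, a lower number a stronger inhibitor
compound 1 `C(=C/c1nc2ccccn2c1Sc1ccccc1)\c1ccccc1` gives 25300 nM
compound 2 `c1ccc(Sc2c(-c3cccs3)nc3ccccn23)cc1` gives 69200 nM

Compound 2 holds the higher of the two numbers in this assay. Compound 3 `Clc1ccc(-c2nc3ccccn3c2Sc2ccccc2)cc1` has not been measured yet. It differs from compound 2 by 4-chlorophenyl in place of thiophen-2-yl on an aromatic carbon, with 4-chlorophenyl in place of thiophen-2-yl on an aromatic carbon. Among the measured compounds shown here, only one measured step bears on this carbon, the modest 2.7-fold higher number from compound 1 to compound 2 (0.44 log units; beyond the scatter). With so little to go on, a modest move back toward a lower number is expected, smaller than or close to that step. The expected change is a 1.7-fold lower number from compound 2 to compound 3 (0.24 log units; within the scatter). For compound 3 the estimated value is 40000 nM, with an expected range of 15000 nM to 90000 nM.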

Compound 3, half-maximal inhibitory concentration: 24500 nM
Estimate against measurement, compound 3: 1.6-fold (0.21 log units) above; measured number inside the range.
By their numbers in this assay, from the lowest: compounds 3 and 1 (each within the scatter of the next); then compound 2.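

In this assay, the change at this aromatic carbon gives a 2.8-fold lower number from compound 2 to compound 3 (0.45 log units; beyond the scatter) (beyond the scatter), so compound 2 now stands apart from two different groups rather than one. The 4-chlorophenyl and 2-phenylethenyl groups are not separated here, with a 1.0-fold lower number from compound 1 to compound 3 (0.01 log units; within the scatter) (within the scatter), so this carbon accepts either group without a readable difference. No evidence at hand explains these results.

Open, going by these compounds, is how an unsubstituted phenyl, a 4-methoxyphenyl, an amine or a carboxylic acid would read on this carbon. On these data alone, whether the phenylsulfanyl group contributes to these numbers also remains unknown.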